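Replacing Chloro with Phenyl on a Bicyclic Nicotinic Agonist

The source may hold more compounds than are shown below. What is called first, only, known or untested is meant among the compounds shown, and "the series" means these compounds.

Compound 1, `Clc1ccc(C2=CC3CNCC(C2)C3)cn1`: 54 nM
Compound 2, `C1=C(c2cccnc2)C[C@@H]2CNC[C@H]1C2`: 2.3 nM
Compound 3, `Clc1ccc(C2=CC3CNCC(C2)C3)nn1`: 80 nM

All three were tested in an in vitro functional assay on SH-EP1 cells for agonist activity at Neuronal acetylcholine receptor; alpha4/beta2 (Homo sapiens), read by FLIPR and calcium flux; a higher number here means that more compound is needed for the effect, a lower number that less compound is needed. Among these three numbers, compound 1 has the second highest. Its nearest neighbour is compound 3, whose number differs from that of compound 1 by less than the usual scatter, so the two cannot be told apart. Compound 2, which carries an unsubstituted pyridine on the shared core, stands furthest away, with a number that is lower by a margin well beyond the scatter.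

The compound not yet measured is compound 4, `C1=C(c2ccc(-c3ccccc3)nc2)CC2CNCC1C2`. Relative to compound 1 the change is phenyl in place of chloro on an aromatic carbon. Among the compounds with values here, no pair among the measured compounds shows this kind of exchange, so the step has to be judged from the structural change alone. A phenyl is a much larger group than a chloro, and compounds 1 and 3 already show that a substituent on that ring goes with a higher number than the unsubstituted compound 2. The expected step from compound 1 to compound 4 is therefore a 5.6-fold higher number from compound 1 to compound 4 (0.74 log units; beyond the scatter), towards a higher number, beyond the scatter. For compound 4 the estimated value in this assay is 300 nM, within a range from 60 nM to 2000 nM.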

Compound 4, half-maximal effective concentration: > 10000 nM
Compound 4 gave a limit, no number; the forecaster's own chance of this, stated with the estimate: 20%; middle value at least 33-fold (1.52 log units) from the limit.
By their numbers in this assay, from the lowest: compound 2; then compounds 1 and 3 (each within the scatter of the next). At a limit, above all of these: compound 4.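

Before compound 4, chloro was the only group shown on this aromatic carbon next to the ring nitrogen, so the earlier compounds could not say how the shared core would respond to a whole aromatic ring at this position in this assay. Compound 4, with phenyl in place of chloro, gives only a limit of the assay and not a number: the limit of > 10000 nM in this assay, at which 1 of the 4 values shown sits. Read with that caution, the exchange brings an at least 180-fold higher number from compound 1 to compound 4 (2.26 log units; beyond the scatter), so this single change at this one position is enough to produce a large step, and its full size stays unknown.

The compounds shown do not reveal whether any group with more heavy atoms than chloro would bring such a step, or whether it belongs to phenyl in particular; a methyl, a methoxy or a small amine on the same carbon would help to separate those two readings. They also leave open whether a pyridine ring in place of phenyl, or a phenyl set further out on a short chain, would give a measurable number in this assay.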